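The compounds below may be only part of what the source reports. "The series", "measured", "known", "first", "only" and "open" are said of these compounds alone.

Measured so far in an assay for inhibition of 17-beta-hydroxysteroid dehydrogenase type 1 (Homo sapiens), read by HPLC, with a stated time of 10 min, tested at 1 uM; a lower number here means less inhibition, a higher number more inhibition at the concentration tested (going by the name of the read-out):
- compound 1, `C=C(c1ccc(F)c(O)c1)c1cccc(-c2cccc(O)c2F)n1`: 88%
- compound 2, `N#Cc1ccc2ccc(C(=O)c3ccc(F)c(O)c3)nc2c1`: "not active" (no number reported)
- compound 3, `Cc1cc(-c2ccc3ccc(C(=O)c4ccc(F)c(O)c4)nc3c2)ccc1O`: 11%

Compound 3 stands lowest of the two entries that carry a number: compound 1 sits well above it, a gap that is beyond the scatter of repeated runs. Compound 2 is reported without a number, only as not active, so its placement relative to compound 3 cannot be put in figures; it shares the carbonyl-linked core of compound 3 and carries a nitrile where compound 3 carries the larger aryl group.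

The next compound, compound 4, is `Nc1ccc2ccc(C(=O)c3ccc(F)c(O)c3)nc2c1`. It differs from compound 3 in one place: amino in place of 4-hydroxy-3-methylphenyl on an aromatic carbon. For the measured compounds named here, no measured pair in the set shows this exact change, so the expectation for it has to rest on compound 2 and compound 3 alone, both on the same core, one with a low number and one reported as not active.

Given that compound 2 gives "not active" (no number reported) and compound 3 gives 11%, compound 4 is expected to stay in that low region, with a step of a number 6 percentage points lower from compound 3 to compound 4 (within the scatter) that is small downward or within the scatter, and a real chance that it is reported without a number at all. The working estimate for compound 4 is 5%, ranging from 0% to 20%.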

Compound 4, a percentage reported as inhibition, at one concentration (the size of the read-out at that concentration, not a potency): 21%
Compound 4: middle estimate off by 16 percentage points, on the low side; measured number outside the range, above it.
By their numbers in this assay, from the lowest: compounds 3 and 4 (each within the scatter of the next); then compound 1.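

On the aromatic carbon, para to a fused ring, in this assay, amino in place of 4-hydroxy-3-methylphenyl gives a step that cannot be told apart from no difference (a number 10 percentage points higher from compound 3 to compound 4 (within the scatter)), so on the shared core the large aryl group and the single-atom amino group read the same at the concentration tested. The two groups match in their hydrogen-bond donor and acceptor counts and neither carries a net charge, yet they differ in size and in the aromatic ring, and that ring is not required for a number in this range. Compound 2, with nitrile at the same place, is reported as ("not active" (no number reported)), while compound 4 carries a number (21%), and no measurement at hand accounts for these readings.

Still open, as far as these compounds go, is how a carboxylic acid, a methoxy group or a dimethylamino group at this position would read on the same core. Compound 1 differs from this series in more than one place, so its number gives no guide to what this position can reach.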